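Cyano for fluoro in a weakly active series

A few compounds are considered here, and "the series" means these few. Any claim that something is new, unique, unknown or untested is made for them only; others in the source may bear on it.

In a functional assay on SMMC-7721 cells (Homo sapiens) for cytotoxicity, read by MTT assay, with a stated time of 24 h (a higher number here means a weaker inhibitor, a lower number a stronger inhibitor), compound 1 `CN1C/C(=C\c2ccncc2)C(=O)/C(=C/c2ccccc2F)C1`, with methyl on an amine nitrogen in a ring, gives 7000 nM. Compound 2 `O=C1/C(=C/c2ccncc2)CN(S(=O)(=O)c2ccccc2)C/C1=C\c1ccccc1F`, with phenylsulfonyl there, gives 17500 nM. Compound 3 `O=C1/C(=C/c2ccncc2)CN(S(=O)(=O)c2ccc(F)cc2)C/C1=C\c1ccccc1F`, with (4-fluorophenyl)sulfonyl there, gives only a limit, > 20000 nM.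

Compound 4 `N#Cc1ccc(S(=O)(=O)N2C/C(=C\c3ccncc3)C(=O)/C(=C/c3ccccc3F)C2)cc1` differs from it in one place: cyano in place of fluoro on an aromatic carbon, para to a large group (cyano in place of fluoro on an aromatic carbon). The closest measured guide is an at least 1.1-fold higher number from compound 2 to compound 3 (0.05 log units; that floor lies within the scatter), a change on that same carbon, and its floor lies within the scatter. The other two steps, a 2.5-fold higher number from compound 1 to compound 2 (0.40 log units; beyond the scatter) and an at least 2.8-fold higher number from compound 1 to compound 3 (0.45 log units; beyond the scatter), are modest, but they replace the methyl rather than alter this carbon.

For the measured compounds named here, no measured step therefore points to a shift beyond the scatter in either direction, and the result may again be only a limit. The expected change is a number no higher from compound 3 to compound 4 (the limit leaves the size open). Compound 4 is estimated at 20000 nM, within an expected range of 9000 nM to 45000 nM.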

Compound 4, half-maximal inhibitory concentration: 16200 nM
For compound 4 the middle estimate is 1.2-fold (0.09 log units) above the measured one; the measured number falls inside the stated range.
By their numbers in this assay, from the lowest: compound 1; then compounds 4 and 2 (each within the scatter of the next). At a limit, above all of these: compound 3.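

Cyano on this carbon gives compound 4 a full reading in this assay, whereas the fluoro compound offers only a limit to compare it with: the limit of > 20000 nM in this assay, at which 1 of the 4 values shown sits.

Read against that limit, the change is an at least 1.2-fold lower number from compound 3 to compound 4 (0.09 log units; that floor lies within the scatter), so cyano and fluoro cannot be ranked here. Set against plain phenylsulfonyl, cyano gives a 1.1-fold lower number from compound 2 to compound 4 (0.03 log units; within the scatter), so adding it to that ring shows no real change, while the swap for the methyl on the ring nitrogen still gives a 2.3-fold higher number from compound 1 to compound 4 (0.36 log units; beyond the scatter) and so matches the two earlier steps from compound 1 in direction.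

On these data alone, the true number for compound 3 stays unknown. Also open, as far as these compounds go, is whether a different group on this carbon, such as an amine or a carboxylic acid, would move the number beyond the scatter.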